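The source may hold more compounds than are shown below. What is called first, only, known or untested is meant among the compounds shown, and "the series" means these compounds.

Three compounds built on one shared core have been examined in an ADME assay on Huh-7 cells (Homo sapiens) for cytotoxicity, read by MTT assay, with a stated time of 72 h; a higher number here means that more compound is tolerated, a lower number that less compound is tolerated. Compound 3 `Cc1cc(=O)oc2cc(OCc3cn(-c4ccccc4F)nn3)ccc12` gives only the limit of the assay, > 100 ug/mL. Compound 1 `Cc1cc(=O)oc2cc(OCc3cn(-c4ccc(F)c(Cl)c4)nn3)ccc12` likewise gives the limit > 100 ug/mL. Compound 2 `Cc1cc(=O)oc2cc(OCc3cn(-c4ccccc4Cl)nn3)ccc12` also gives the limit > 100 ug/mL. Because all three values sit at the limit of > 100 ug/mL in this assay, at which 3 of the 3 values shown sit, the steps a step that the two limits leave unreadable from compound 1 to compound 2, a step that the two limits leave unreadable from compound 1 to compound 3 and a step that the two limits leave unreadable from compound 2 to compound 3 cannot be sized in either direction. Compound 4 `Cc1cc(=O)oc2cc(OCc3cn(-c4ccc(Cl)cc4)nn3)ccc12` differs from compound 3 by 4-chlorophenyl in place of 2-fluorophenyl on an aromatic nitrogen. Since no measured step can be read, no shift beyond the scatter is expected in this assay. Compound 4 is estimated at 150 ug/mL, with a range from 100 ug/mL to 300 ug/mL. The expected step is therefore a step that the limit leaves unreadable from compound 3 to compound 4, nothing beyond the scatter, and most likely another limit.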

Compound 4, half-maximal cytotoxic concentration: > 100 ug/mL
Compound 4 gave a limit, no number; the forecaster's own chance of this, stated with the estimate: 85%; the middle value lies beyond the limit too.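

Compound 4 also gives a limit, > 100 ug/mL, so its steps to compound 1, compound 2 and compound 3 cannot be read: the limit of > 100 ug/mL in this assay, at which 4 of the 4 values shown sit. In this assay the compounds shown leave open at what concentration any of them becomes cytotoxic, and whether changing the substituted phenyl group shifts that concentration.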